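The source may hold more compounds than are shown below. What is called first, only, known or untested is meant among the compounds shown, and "the series" means these compounds.

Measured in a functional assay on MCF7 cells (Homo sapiens) for inhibition, read by MTT assay; on this read-out lower numbers stand for stronger inhibition of growth and higher numbers for weaker inhibition of growth:
compound 1 `COc1cc2oc(-c3cccc(NC(=O)c4ccc(Br)cc4)c3)cc(=O)c2c(OC)c1OC`: 9650 nM
compound 2 `COc1cc2oc(-c3cccc(NC(=O)c4ccccc4Br)c3)cc(=O)c2c(OC)c1OC`: 55000 nM
compound 3 `COC(=O)c1ccc(C(=O)Nc2cccc(-c3cc(=O)c4c(OC)c(OC)c(OC)cc4o3)c2)cc1`: 30300 nM

Of the three values, two form a higher pair that includes compound 3: a 1.8-fold lower number from compound 2 to compound 3 (0.26 log units; within the scatter). Compound 1 has the lowest number.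

The next change gives compound 4 `COc1cc2oc(-c3cccc(NC(=O)c4ccc(C(F)(F)F)cc4)c3)cc(=O)c2c(OC)c1OC`, with trifluoromethyl in place of methoxycarbonyl on an aromatic carbon, para to a large group: trifluoromethyl in place of methoxycarbonyl on an aromatic carbon.

The most relevant measured change swaps the group at this same place: a 3.1-fold higher number from compound 1 to compound 3 (0.50 log units; beyond the scatter). Moving the bromo gives a larger step, a 5.7-fold higher number from compound 1 to compound 2 (0.76 log units; beyond the scatter), but this changes where the group sits, not which group it is, so it bears less directly. Among the measured compounds shown here, no trifluoromethyl analogue has been measured yet, so the expectation is loose: a small move towards a lower number in this assay, inside the span set by the two groups measured at this place.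

The expected size of the change is a 1.9-fold lower number from compound 3 to compound 4 (0.28 log units; within the scatter), which is small and uncertain in direction.

For compound 4 the estimate is 16000 nM, with an expected range of 6000 nM to 45000 nM.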

Compound 4, concentration for 50% growth inhibition: 10600 nM
Compound 4: middle estimate off by 1.5-fold (0.18 log units), on the high side, within the range that was stated.
By their numbers in this assay, from the lowest: compounds 1 and 4 (each within the scatter of the next); then compounds 3 and 2 (each within the scatter of the next).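

In this assay, trifluoromethyl on this aromatic carbon, para to a large group, groups with bromo rather than with methoxycarbonyl: a 2.9-fold lower number from compound 3 to compound 4 (0.46 log units; beyond the scatter), whereas a 1.1-fold higher number from compound 1 to compound 4 (0.04 log units; within the scatter), so bromo and trifluoromethyl cannot be told apart here. The step from the 2-bromophenyl amide is of similar size, a 5.2-fold lower number from compound 2 to compound 4 (0.72 log units; beyond the scatter), so among these four compounds, 4-bromophenyl and 4-(trifluoromethyl)phenyl form the lower pair, and 4-(methoxycarbonyl)phenyl and 2-bromophenyl the higher. No measured property is available to explain why methoxycarbonyl and trifluoromethyl differ at this place.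

Going by these compounds, it remains open whether a nitrile, a carboxylic acid or an amine at this place would fall with the lower pair or with methoxycarbonyl. On these data alone, it is also open whether trifluoromethyl would show the same step as bromo if it were moved to the position bromo holds in compound 2.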